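Swapping a sec-butyl for phenyl on the amino-acid carbon

The source may report more compounds than this note shows. Statements on the series, on what has been measured and on what is new or still open speak of the compounds shown alone.

Three esters that share one long-chain core have been tested in a functional assay on SK-OV-3 cells (Homo sapiens) for cytotoxicity, read by MTT assay; on this read-out higher numbers stand for weaker inhibition and lower numbers for stronger inhibition. Compound 1 `CCCCCCCCC(CCCCCCCCC(=O)OC)SCC(=O)NCC(=O)OC` carries only hydrogen on the saturated chain carbon bound to an amide-type nitrogen and a carbonyl carbon, and in this assay compound 1 gives 25200 nM. Compound 2 `CCCCCCCCC(CCCCCCCCC(=O)OC)SCC(=O)N[C@@H](C)C(=O)OC` has a methyl at that position, and compound 2 gives 114000 nM. Compound 3 `CCCCCCCCC(CCCCCCCCC(=O)OC)SCC(=O)N[C@H](C(=O)OC)[C@@H](C)CC` has a sec-butyl there, and compound 3 gives 16400 nM. Compound 3 sits at the low end of these three numbers: it is separated from compound 1 by a 1.5-fold lower number from compound 1 to compound 3 (0.19 log units; within the scatter), and from compound 2 by a 7.0-fold lower number from compound 2 to compound 3 (0.84 log units; beyond the scatter). The step of a 4.5-fold higher number from compound 1 to compound 2 (0.66 log units; beyond the scatter) shows that the small methyl made matters worse, while the step to sec-butyl recovered and slightly passed the unsubstituted starting point.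

Compound 4 `CCCCCCCCC(CCCCCCCCC(=O)OC)SCC(=O)N[C@H](C(=O)OC)c1ccccc1` is the next member, differing from compound 3 by phenyl in place of sec-butyl on a saturated chain carbon bound to an amide-type nitrogen and a carbonyl carbon. Going by the values given here, both sec-butyl and phenyl are sizeable groups at this position, and the measured steps give no example of an aromatic ring here, so the expectation rests on the sec-butyl compound alone. The step from compound 3 to compound 4 in this assay is therefore expected to be small, about a 1.1-fold lower number from compound 3 to compound 4 (0.04 log units; within the scatter). For compound 4 the expected value is 15000 nM, with a range from 6000 nM to 40000 nM.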

Compound 4, half-maximal inhibitory concentration: 42500 nM
Compound 4: the middle estimate sits 2.8-fold (0.45 log units) below what was measured, outside the stated range (above it).
By their numbers in this assay, from the lowest: compounds 3, 1 and 4 (each within the scatter of the next, the first and the last beyond it); then compound 2.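

Changing sec-butyl to phenyl gives a 2.6-fold higher number from compound 3 to compound 4 (0.41 log units; beyond the scatter) in this assay, so this position can distinguish between two carbon groups that both have several heavy atoms. The phenyl compound still differs clearly from the methyl compound, with a 2.7-fold lower number from compound 2 to compound 4 (0.43 log units; beyond the scatter), but the comparison with the hydrogen compound gives only a 1.7-fold higher number from compound 1 to compound 4 (0.23 log units; within the scatter), so phenyl and hydrogen cannot be told apart at this position. Across the four compounds, the numbers therefore do not change steadily with the heavy-atom count of the group: methyl gives the highest number of the set, while sec-butyl and phenyl, the two larger groups, differ from each other.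

No measurement here accounts for why the phenyl and sec-butyl compounds differ. Going by these compounds, it also remains open whether a cyclohexyl, which has a ring without aromatic character, or a benzyl on the saturated chain carbon bound to an amide-type nitrogen and a carbonyl carbon would give a number closer to that of the sec-butyl compound or to that of the phenyl compound.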